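This account rests on a few compounds, and the source may have more. Where it says the series, first, only, none or still open, it means among the compounds named here.

The account follows the step from compound 2 `CCCCCCCCCCCC[C@@H](O)[C@H]1CC[C@H]([C@H](O)CCCCCCCCCCC(=O)Nc2ccnn2C)O1` to compound 3 `CCCCCCCCCCCC[C@@H](O)[C@H]1CC[C@H]([C@H](O)CCCCCCCCCCOC(=O)c2ccnn2C)O1`. Among the measured compounds shown here, in a functional assay on HCT-15 cells (Homo sapiens) for inhibition, read by sulforhodamine B assay, with a stated time of 48 h (on this read-out lower numbers stand for stronger inhibition of growth and higher numbers for weaker inhibition of growth), compound 2 gives 100000 nM, the highest of the two numbers measured so far. For the measured compounds named here, its only neighbour is compound 1 `CCCCCCCCCCCC[C@@H](O)[C@H]1CC[C@H]([C@H](O)CCCCCCCCCCNCc2ccnn2C)O1`, which in this assay gives 2000 nM; the step of a 50-fold higher number from compound 1 to compound 2 (1.70 log units; beyond the scatter) is the only measured step available, and it concerns a different change, from an amine to an amide.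

Compound 3 carries the change (((1-methyl-1H-pyrazol-5-yl)carbonyl)oxy in place of (1-methyl-1H-pyrazol-5-yl)carbamoyl on a saturated chain carbon, ten or more bonds along the chain from an oxygen on a saturated carbon and a saturated ring carbon). Going by the values given here, no measured step covers this exchange of the carbamoyl group for the carbonyloxy group; the step of a 50-fold higher number from compound 1 to compound 2 (1.70 log units; beyond the scatter) shows only that the carbamoyl-bearing compound 2 sits far from the amine-bearing compound 1, and the ester of compound 3 is closer in kind to the amide of compound 2 than to that amine. The author therefore expects no step beyond the scatter, or at most a moderate one, a 1.7-fold lower number from compound 2 to compound 3 (0.22 log units; within the scatter), with direction uncertain. Compound 3 is estimated at 60000 nM in this assay, with a range from 15000 nM to 200000 nM.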

Compound 3, concentration for 50% growth inhibition: 47900 nM
Compound 3: the middle estimate sits 1.3-fold (0.10 log units) above what was measured, within the range that was stated.
By their numbers in this assay, from the lowest: compound 1; then compound 3; then compound 2.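

In this assay, putting the ((1-methyl-1H-pyrazol-5-yl)carbonyl)oxy group in place of the (1-methyl-1H-pyrazol-5-yl)carbamoyl group on this saturated chain carbon gives a 2.1-fold lower number from compound 2 to compound 3 (0.32 log units; beyond the scatter), so the exchange of amide for ester, which also removes the amide hydrogen-bond donor, shifts the number only modestly. The ester remains far from the amine, with a 24-fold higher number from compound 1 to compound 3 (1.38 log units; beyond the scatter), so among these three compounds both the amide and the ester lie well above compound 1, and the ((1-methyl-1H-pyrazol-5-yl)methyl)amino group goes with the lowest number. Nothing available here gives a measured reason for either step.

The compounds shown leave open whether the lower number of compound 1 belongs to the amine itself or depends on the 1-methyl-1H-pyrazol-5-yl group attached to it. As far as these compounds go, it also remains open what a tertiary amine or a carboxylic acid on the same chain carbon would give, and whether the order of amine, ester and amide would hold on a shorter chain.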